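Benzyl ester of compound 1 in the oral tail flick test

This account rests on a few compounds, and the source may have more. Where it says the series, first, only, none or still open, it means among the compounds named here.

Measured compounds in a functional assay on the whole organism (Tail, strain ICR) with Mus musculus as the target, in the tail flick test, with a stated time of 150 min, at a dose of 25 umol/kg by the oral route; a higher number here means a stronger effect of the compound at the dose given, a lower number a weaker effect:
compound 1 `C[C@@H](O)[C@H](NC(=O)CN(c1nc(Cl)nc2[nH]cnc12)C1CC1)C(=O)O` gives 24%
compound 2 `C[C@H](NC(=O)CN(c1nc(Cl)nc2[nH]cnc12)C1CC1)C(=O)O` gives 14.7%
compound 3 `CC(C)C[C@H](NC(=O)CN(c1nc(Cl)nc2[nH]cnc12)C1CC1)C(=O)O` gives 9.13%

Compound 1 has the highest number of the three in this assay. The gap to compound 2, a number 9.3 percentage points lower from compound 1 to compound 2 (within the scatter), lies within the scatter, so no order between compound 1 and compound 2 can be read from it. The gap to compound 3, a number 14.9 percentage points lower from compound 1 to compound 3 (beyond the scatter), is beyond the scatter and modest. Between compound 2 and compound 3 the step of a number 5.6 percentage points lower from compound 2 to compound 3 (within the scatter) again stays within the scatter.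

Compound 4 `C[C@@H](O)[C@H](NC(=O)CN(c1nc(Cl)nc2[nH]cnc12)C1CC1)C(=O)OCc1ccccc1` differs from compound 1 at the acid end of the chain rather than at the side chain: benzyl in place of hydrogen on an oxygen next to a carbonyl group. None of the three measured steps touches the oxygen next to the carbonyl group; all of them vary the substituent on the saturated chain carbon bound to the amide-type nitrogen and the carbonyl carbon. Those steps were at most modest in size, and they give no guidance on a benzyl in place of hydrogen at the carboxy group.

Within the data shown here, with no bearing step, the expectation for compound 4 rests on compound 1 alone, and the expected step of a number 1 percentage points higher from compound 1 to compound 4 (within the scatter) is set near zero with a wide range. Compound 4 is therefore estimated at 25%, between 8% and 45%.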

Compound 4, a percentage reported as activity, at one dose (the size of the read-out at that dose, not a potency): 12.8%
Beside the measured number, compound 4's estimate is 12.2 percentage points above it; measured number inside the range.
By their numbers in this assay, from the lowest: compounds 3, 4, 2 and 1 (each within the scatter of the next, the first and the last beyond it).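

In this assay, among these compounds, the change from carboxy to benzyloxycarbonyl gives the first reading at the acid end of the chain, and the step of a number 11.2 percentage points lower from compound 1 to compound 4 (beyond the scatter) shows that this position affects the read-out at the dose given. The change at this oxygen carries as much weight as the largest side-chain change on compound 1, the step of a number 14.9 percentage points lower from compound 1 to compound 3 (beyond the scatter), since both are printed as modest and beyond the scatter, so the side chain is no longer the only place in the series where the number moves. Nothing measured on these compounds explains why the benzyl group lowers the number, and no supporting data bear on this result.

A single ester leaves open whether the step belongs to the benzyl group, with its six-membered aromatic ring of carbon only, or to capping the carboxy group at all, which a methyl ester, an ethyl ester or a primary amide at the same place would help to separate. Also open, from the compounds shown here alone, is whether benzyloxycarbonyl changes the number by a similar step when it is paired with the methyl side chain of compound 2 or the isobutyl side chain of compound 3.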